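Swapping the Group on the Ring Nitrogen of Compound 3

A few compounds are considered here, and "the series" means these few. Any claim that something is new, unique, unknown or untested is made for them only; others in the source may bear on it.

In a physicochemical assay for lipophilicity, at pH 7.4 (a higher number here means a more lipophilic compound, a lower number a more polar compound), compound 3 (`CCc1ccc(N(CC(C)C)S(=O)(=O)c2ccc3c(c2)C(=O)CC(C2CCN(C(=O)OC(C)(C)C)CC2)O3)cc1`) gives 5.1, the highest of the three measured numbers. The nearest is compound 2 (`CCc1ccc(N(CC(C)C)S(=O)(=O)c2ccc3c(c2)C(=O)CC(C2CCN(S(=O)(=O)C4CCCC4)CC2)O3)cc1`) at 4.75, and the furthest is compound 1 (`CCc1ccc(N(CC(C)C)S(=O)(=O)c2ccc3cc(OCC4CCOCC4)c(C(=O)O)cc3c2)cc1`) at 1.77.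

Compound 4 (`CCc1ccc(N(CC(C)C)S(=O)(=O)c2ccc3c(c2)C(=O)CC(C2CCN(S(C)(=O)=O)CC2)O3)cc1`) has not yet been measured. It has methylsulfonyl in place of tert-butoxycarbonyl on an amine nitrogen in a ring.

Among the measured compounds shown here, one measured step concerns this same nitrogen, and it is modest: a number 0.35 log units higher from compound 2 to compound 3 (beyond the scatter), with tert-butoxycarbonyl in place of cyclopentylsulfonyl. Compound 4 resembles compound 2 in carrying a sulfonyl group, but methylsulfonyl is the smaller of the two. For the measured compounds named here, a fall larger than that measured step therefore seems likely, although no measured pair compares these two sulfonyl groups directly. The expected change is a number 1.00 log units lower from compound 3 to compound 4 (beyond the scatter). For compound 4 the estimated value is 4.1, with an expected range from 3.7 to 4.5.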

Compound 4, distribution coefficient: 3.31
Beside the measured number, compound 4's estimate is 0.79 log units above it; measured number outside the range, below it.
By their numbers in this assay, from the lowest: compound 1; then compound 4; then compound 2; then compound 3.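

In this assay, among the compounds shown here, the group on this ring nitrogen turns out to matter far more than the one earlier step suggested: methylsulfonyl in place of tert-butoxycarbonyl gives a number 1.79 log units lower from compound 3 to compound 4 (beyond the scatter) and counts as a large change. Keeping the sulfonyl and altering only what it carries, methyl in place of cyclopentyl on the sulfonyl sulfur, gives a number 1.44 log units lower from compound 2 to compound 4 (beyond the scatter) and is also large, so sharing a sulfonyl does not put two compounds close together, and compound 2 lies nearer to compound 3 than to compound 4. Nothing measured here explains the size of either step.

The compounds shown leave open whether the number climbs gradually or jumps for a sulfonyl carrying a chain such as propyl or isopropyl. Also open, on these data alone, is where an acetyl group or a free amine at this nitrogen would fall.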